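A few compounds are considered here, and "the series" means these few. Any claim that something is new, unique, unknown or untested is made for them only; others in the source may bear on it.

Measured so far:
compound 1 `Cc1ccc(C(=O)c2cc(Cl)ccc2Oc2ccnc(Nc3ccc(C#N)cc3)n2)cc1` — 1710 nM
compound 2 `COc1ccc(C(=O)c2ccccc2)c(Oc2ccnc(Nc3ccc(C#N)cc3)n2)c1` — 760 nM
compound 3 `COc1ccc(C(=O)c2ccccc2)c(Oc2cc(C)nc(Nc3ccc(C#N)cc3)n2)c1` — 4900 nM

All three were tested in an ADME assay on MT4 cells (Homo sapiens) for cytotoxicity, read by MTT assay, with a stated time of 5 days; on this read-out lower numbers stand for higher toxicity in this test and higher numbers for lower toxicity in this test. The difference between the cores of compound 1 and compound 2 is not broken down here. Compound 3 differs from compound 2 by methyl in place of hydrogen on an aromatic carbon, and that change gave a 6.4-fold higher number from compound 2 to compound 3 (0.81 log units; beyond the scatter).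

Compound 4 `Cc1ccc(C(=O)c2cc(Cl)ccc2Oc2nc(Nc3ccc(C#N)cc3)ncc2C)cc1` has not yet been measured in this assay. It differs from compound 1 by methyl in place of hydrogen on an aromatic carbon. This is the same kind of change as the earlier one, but the place is not the same: in compound 3 the methyl sits next to the ring nitrogen, meta to the (4-cyanophenyl)amino group, meta to a large group and opposite the ring nitrogen, whereas in compound 4 it sits ortho to a large group, two atoms from the ring nitrogen and para to the (4-cyanophenyl)amino group. Resting on a 6.4-fold higher number from compound 2 to compound 3 (0.81 log units; beyond the scatter) and on compound 1 at 1710 nM, the step to compound 4 is expected to be a 2.3-fold higher number from compound 1 to compound 4 (0.37 log units; beyond the scatter), a smaller step than the earlier one as the place is not the same. Compound 4 is expected to give 4000 nM, with a likely range from 1500 nM to 12000 nM.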

Compound 4, half-maximal cytotoxic concentration: >= 830 nM
Compound 4: only a limit was reported; the forecaster's own chance of this, stated with the estimate: 20%; the middle value does not contradict the limit.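

In this assay, for the compounds shown here, compound 4 gives >= 830 nM, which is a limit and not a number, so no step from compound 1 to compound 4 can be read. The compounds shown leave open whether methyl at this place changes the number as much as the methyl of compound 3 did.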